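This account rests on a few compounds, and the source may have more. Where it says the series, first, only, none or still open, it means among the compounds named here.

The measured compounds:
compound 1 `O=C(CSc1nc2ccccc2[nH]1)c1ccc(Br)cc1`, in a functional assay on HT-29 cells (Homo sapiens) for inhibition, read by WST assay, with a stated time of 48 h (a higher number here means a weaker inhibitor, a lower number a stronger inhibitor), compound 1 gives 43000 nM
compound 2 `O=C(CSc1nc2ccccc2[nH]1)c1ccc(O)cc1`, compound 2 gives 19200 nM
compound 3 `O=C(CSc1nc2ccccc2[nH]1)c1ccc([N+](=O)[O-])cc1`, compound 3 gives 57000 nM

Compound 3 stands at the highest number of the three, but its distance from compound 1 is within the scatter (a 1.3-fold higher number from compound 1 to compound 3 (0.12 log units; within the scatter)), and only against compound 2 does the number rise beyond it (a 3.0-fold higher number from compound 2 to compound 3 (0.47 log units; beyond the scatter)). Compound 4 `O=C(CSc1nc2ccccc2[nH]1)c1ccccc1` differs from compound 3 in one place: hydrogen in place of nitro on an aromatic carbon. Within the data shown here, no measured step puts hydrogen at that carbon; the bearings are the step from bromo to nitro (a 1.3-fold higher number from compound 1 to compound 3 (0.12 log units; within the scatter)), from hydroxy to nitro (a 3.0-fold higher number from compound 2 to compound 3 (0.47 log units; beyond the scatter)) and from bromo to hydroxy (a 2.2-fold lower number from compound 1 to compound 2 (0.35 log units; beyond the scatter)), all modest or within the scatter. The three substituents therefore span only a narrow band of numbers, and an unsubstituted ring is expected to fall inside that band, nearer compound 1 than compound 2. Compound 4 is accordingly expected to give a lower number by only a 1.4-fold lower number from compound 3 to compound 4 (0.15 log units; within the scatter), a step that may stay within the scatter. Compound 4 is estimated at 40000 nM, with a range from 15000 nM to 90000 nM.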

Compound 4, half-maximal inhibitory concentration: 38500 nM
For compound 4 the middle estimate is 1.0-fold (0.02 log units) above the measured one; the measured number falls inside the stated range.
By their numbers in this assay, from the lowest: compounds 2, 4, 1 and 3 (each within the scatter of the next, the first and the last beyond it).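

With hydrogen at this aromatic carbon, para to a large group, this assay gains an unsubstituted reference, and all three substituents lie within the scatter of it: hydrogen in place of nitro gives (a 1.5-fold lower number from compound 3 to compound 4 (0.17 log units; within the scatter)), hydrogen in place of hydroxy gives (a 2.0-fold higher number from compound 2 to compound 4 (0.30 log units; within the scatter)) and hydrogen in place of bromo gives (a 1.1-fold lower number from compound 1 to compound 4 (0.05 log units; within the scatter)). The steps beyond the scatter (a 2.2-fold lower number from compound 1 to compound 2 (0.35 log units; beyond the scatter)) and (a 3.0-fold higher number from compound 2 to compound 3 (0.47 log units; beyond the scatter)) therefore run only between two substituents, and none separates a substituent from hydrogen. No measurement at hand bears on what lies behind these numbers.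

The compounds shown leave open whether any group at this carbon can move the number far from the narrow band they occupy. From the compounds shown here alone, an amine, a carboxylic acid or a methoxy group there would be a further test, and the rest of the shared core remains unexplored.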